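A few compounds are considered here, and "the series" means these few. Any claim that something is new, unique, unknown or untested is made for them only; others in the source may bear on it.

Working notes on a set of esters sharing one core, measured in an assay on membranes from CHO cells for displacement of a labelled ligand from adenosine receptor A1 (Homo sapiens), read by scintillation counting, with a stated time of 60 min, tested at 1 uM; on this read-out lower numbers stand for less inhibition and higher numbers for more inhibition at the one concentration tested (going by the name of the read-out). Compound 3 `CCCOC(=O)C1=C(C)NC(=S)NC1c1ccsc1` gives 5%. Compound 2 `COC(=O)C1=C(C)NC(=S)NC1c1ccsc1` gives 3%, and compound 1 `CC1=C(C(=O)OCC(C)C)C(c2ccoc2)NC(=S)N1` gives 12%. Compound 3 stands second highest of the three numbers, with compound 2 nearest and compound 1 furthest, and both gaps lie within the scatter. Among the compounds with values here, the only single-point step measured in this assay, a number 2 percentage points higher from compound 2 to compound 3 (within the scatter), also stayed within the scatter.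

Compound 4 `CC1=C(C(=O)OCC(C)C)C(c2ccsc2)NC(=S)N1` differs from compound 3 by methyl in place of hydrogen on a saturated chain carbon bound to two saturated chain carbons. Within the data shown here, no step of exactly this kind has been measured; the one chain change seen, a number 2 percentage points higher from compound 2 to compound 3 (within the scatter), gives no reason to expect movement beyond the scatter, so a step of a number 1 percentage points higher from compound 3 to compound 4 (within the scatter) is expected. Compound 4 is therefore estimated at 6%, with a range from 0% to 15%.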

Compound 4, a percentage reported as inhibition, at one concentration (the size of the read-out at that concentration, not a potency): 8%
For compound 4 the middle estimate is 2 percentage points below the measured one; low and high end bracket the measured number.
By their numbers in this assay, from the lowest: compounds 2, 3, 4 and 1 (each within the scatter of the next).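

The branch, propoxy to isobutoxy, gives a number 3 percentage points higher from compound 3 to compound 4 (within the scatter) in this assay, so a methyl on this saturated chain carbon stays within the scatter. The larger change on the saturated chain carbon bound to an oxygen next to a carbonyl group, isopropyl in place of hydrogen, gives a number 5 percentage points higher from compound 2 to compound 4 (within the scatter) and the ring change on the saturated ring carbon gives a number 4 percentage points lower from compound 1 to compound 4 (within the scatter), which extends the same reading to both places. No measurement at hand accounts for these steps.

From the compounds shown here alone, whether an ester with a longer chain such as hexyl, or a phenyl in place of thiophen-3-yl on the saturated ring carbon, would give a step beyond the scatter stays open.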